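Trading 4-nitrophenyl for 3-fluorophenyl in compound 3

A few compounds are considered here, and "the series" means these few. Any claim that something is new, unique, unknown or untested is made for them only; others in the source may bear on it.

In a functional assay on HeLa cells (Homo sapiens) for inhibition, with a stated time of 72 h (on this read-out higher numbers stand for an effect only at larger amounts of compound and lower numbers for an effect already at smaller amounts), compound 1 (`COc1cc(CNCc2ccncc2)ccc1OCc1ccc(Cl)c(Cl)c1`) gives 4000 nM and compound 2 (`COc1cc(CNCc2ccncc2)ccc1OCc1ccc([N+](=O)[O-])cc1`) gives 440 nM as the lower of the two numbers. Compound 3 (`COc1cc(CNCc2ccncc2)ccc1OCc1cccc(F)c1`) carries 3-fluorophenyl in place of 4-nitrophenyl on a saturated chain carbon bound to an oxygen on an aromatic ring. Going by the values given here, the one measured step bearing on this is a 9.1-fold lower number from compound 1 to compound 2 (0.96 log units; beyond the scatter) where 4-nitrophenyl replaced 3,4-dichlorophenyl at that place. With 4-nitrophenyl gone, part of that step is expected to reverse, toward a higher number in this assay and not a lower one. The expected change is a 3.0-fold higher number from compound 2 to compound 3 (0.47 log units; beyond the scatter) by this estimate. Compound 3 is estimated at 1300 nM with 350 nM to 5000 nM as its likely range.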

Compound 3, half-maximal effective concentration: 4800 nM
Compound 3: middle estimate off by 3.7-fold (0.57 log units), on the low side; low and high end bracket the measured number.
By their numbers in this assay, from the lowest: compound 2; then compounds 1 and 3 (each within the scatter of the next).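

Replacing 4-nitrophenyl with 3-fluorophenyl gives an 11-fold higher number from compound 2 to compound 3 (1.04 log units; beyond the scatter) at this place, a large step. Replacing 3,4-dichlorophenyl with 3-fluorophenyl gives a 1.2-fold higher number from compound 1 to compound 3 (0.08 log units; within the scatter) here, so the two halogen-bearing rings cannot be told apart and only the 4-nitrophenyl ring stands out. Nothing measured here accounts for that difference.

As far as these compounds go, whether the lower number of compound 2 depends on the nitro group itself remains open. A nitrile or a carboxylic acid in place of the nitro group would test this.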